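Methoxy in place of methyl: expected maximal response

The compounds below may be only part of what the source reports. "The series", "measured", "known", "first", "only" and "open" are said of these compounds alone.

Compound 1, `CC#C[C@@H](CC(=O)O)c1ccc(OC[C@H]2COc3ccc(F)cc3O2)cc1`, gives 86% in a functional assay on HEK293 cells for agonist activity at Free fatty acid receptor 1 (Homo sapiens), read by fluorescence and calcium flux, with a stated time of 10 min; on this read-out higher numbers stand for larger maximal responses and lower numbers for smaller maximal responses.
Compound 2, `CC#C[C@@H](CC(=O)O)c1ccc(OC[C@H]2COc3ccc(Br)cc3O2)cc1`, gives 69% in this assay.
Compound 3, `CC#C[C@@H](CC(=O)O)c1ccc(OC[C@H]2COc3ccc(C)cc3O2)cc1`, gives 78% in this assay.

Compound 3 stands second highest of the three numbers, yet both of its gaps fall within the scatter: a number 8 percentage points lower from compound 1 to compound 3 (within the scatter) and a number 9 percentage points higher from compound 2 to compound 3 (within the scatter). For the measured compounds named here, the only step beyond the scatter in this set is a number 17 percentage points lower from compound 1 to compound 2 (beyond the scatter), a modest drop.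

Compound 4, `CC#C[C@@H](CC(=O)O)c1ccc(OC[C@H]2COc3ccc(OC)cc3O2)cc1`, differs from compound 3 in one place: methoxy in place of methyl on an aromatic carbon. Going by the values given here, no measured compound carries methoxy on this carbon, so the steps that bear on the change are the three that alter the same aromatic carbon; two of them stay within the scatter and the third is modest. The change is therefore expected to give no step beyond the scatter, or at most a small one in either direction, and the estimated step is a number 2 percentage points lower from compound 3 to compound 4 (within the scatter). Compound 4 is expected to reach 76% in this assay, with an estimated range from 60% to 90%.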

Compound 4, largest response reached (Emax), in percent of the reference or control that the assay uses: 91%
The estimate for compound 4 lay 15 percentage points below the measured number, outside the stated range (above it).
By their numbers in this assay, from the lowest: compounds 2, 3, 1 and 4 (each within the scatter of the next, the first and the last beyond it).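

Methoxy on this aromatic carbon gives a number 13 percentage points higher from compound 3 to compound 4 (beyond the scatter) in this assay, a modest rise from methyl, whereas the earlier steps involving methyl all stayed within the scatter. Against bromo the same group gives a number 22 percentage points higher from compound 2 to compound 4 (beyond the scatter), also modest and beyond the scatter, while against fluoro it gives a number 5 percentage points higher from compound 1 to compound 4 (within the scatter) and stays within the scatter, so methoxy and fluoro cannot be told apart on this read-out. Nothing available bears on what lies behind these differences.

Still open, from the compounds shown here alone, is how other groups on this carbon compare with methoxy and fluoro in this assay, for example a hydroxyl, an amine or a longer alkoxy chain such as ethoxy. Also open, going by these compounds, is whether the rise from methyl to methoxy holds on a core other than that of compound 3.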